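The source may hold more compounds than are shown below. What is called first, only, known or untested is meant among the compounds shown, and "the series" means these compounds.

For the measured compounds named here, compound 1 `CC(C)(C)c1[nH]cnc1/C=c1\[nH]c(=O)/c(=C/c2cccc(C(=O)c3ccccc3)c2)[nH]c1=O` gives the lowest of the two numbers measured so far in a functional assay on BXPC-3 cells (Homo sapiens) for antiproliferative activity, read by sulforhodamine B assay, with a stated time of 72 h (on this read-out lower numbers stand for stronger inhibition and higher numbers for weaker inhibition), at 0.63 nM. Compound 2 `O=C(c1ccccc1)c1cccc(/C=c2\[nH]c(=O)/c(=C/c3ccccn3)[nH]c2=O)c1` gives 6.27 nM, and the step of a 10-fold higher number from compound 1 to compound 2 (1.00 log units; beyond the scatter) changes the group at the other end of the shared core. Compound 3 `CC(C)(C)c1[nH]cnc1/C=c1\[nH]c(=O)/c(=C/c2cccc(C(=O)N3CCCCC3)c2)[nH]c1=O` differs from compound 1 by piperidin-1-yl in place of phenyl on a carbonyl carbon. Going by the values given here, no measured step touches this carbonyl carbon, so the change is untested here. Because compound 1 gives only 0.63 nM as the starting point, compound 3 is expected to give a step of about a 2.4-fold higher number from compound 1 to compound 3 (0.38 log units; beyond the scatter), within the scatter or slightly weaker, so compound 3 is estimated at 1.5 nM, between 0.4 nM and 6 nM.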

Compound 3, half-maximal inhibitory concentration: 100 nM
Compound 3: the middle estimate sits 67-fold (1.82 log units) below what was measured, outside the stated range (above it).
By their numbers in this assay, from the lowest: compound 1; then compound 2; then compound 3.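

Putting piperidin-1-yl in place of phenyl on the carbonyl carbon produces a 160-fold higher number from compound 1 to compound 3 (2.20 log units; beyond the scatter) in this assay and shows that this position, untouched by the earlier step, does not accept every six-membered ring. Both groups are six-membered rings, yet the aromatic all-carbon ring of compound 1 and the non-aromatic ring holding a nitrogen in compound 3 lie far apart on this read-out. Nothing available here explains the loss.

Still open, on these data alone, is whether a cyclohexyl or a morpholin-4-yl group on this carbonyl carbon would stay close to compound 1 or fall towards compound 3.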